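The source may hold more compounds than are shown below. What is called first, only, known or untested is meant among the compounds shown, and "the series" means these compounds.

Values in a functional assay on HT-29 cells (Homo sapiens) for antiproliferative activity, read by sulforhodamine B assay, with a stated time of 48 h; a higher number here means a weaker inhibitor, a lower number a stronger inhibitor:
compound 1 `CCN1CCN(c2ccc(S(=O)(=O)Oc3ccccc3OC)cc2)C1=O`: > 100000 nM, a limit of the assay
compound 2 `CCN1CCN(c2ccc(S(=O)(=O)Oc3cccc(OC)c3)cc2)C1=O`: 22000 nM

For the measured compounds named here, compound 2 holds the only actual number so far, and its sole comparison is with a limit. Compound 3 `CCCCN1CCN(c2ccc(S(=O)(=O)Oc3cccc(OC)c3)cc2)C1=O` differs from it by ethyl in place of hydrogen on a saturated chain carbon, two bonds along the chain from an amide-type nitrogen in a ring, which turns the ethyl chain of compound 2 into a butyl chain. One measured step is available, an at least 4.5-fold lower number from compound 1 to compound 2 (0.65 log units; beyond the scatter), and it concerns 3-methoxyphenyl in place of 2-methoxyphenyl rather than the chain. Its size rests on (the limit of > 100000 nM in this assay, at which 1 of the 2 values shown sits). It therefore gives no direct measure for the chain change, and no direction can be drawn from it. No clear shift is expected, only a wide uncertainty on either side. The expected step is a 1.2-fold lower number from compound 2 to compound 3 (0.09 log units; within the scatter). For compound 3 the estimated value is 18000 nM, with an expected range of 5000 nM to 65000 nM.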

Compound 3, half-maximal inhibitory concentration: 13000 nM
The estimate for compound 3 lay 1.4-fold (0.14 log units) above the measured number; the measured number falls inside the stated range.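

In this assay, for the compounds shown here, the chain change gives the first comparison between two actual numbers: a 1.7-fold lower number from compound 2 to compound 3 (0.23 log units; within the scatter). At this position, the ethyl chain of compound 2 and the butyl chain of compound 3 cannot be told apart in this read-out, so the added carbons bring no shift beyond the scatter. No measured property shown here bears on this chain change.

On these data alone, whether a longer chain, or a chain ending in an amine or a carboxylic acid, would separate from compound 2 and compound 3 remains open. Also open, as far as these compounds go, is whether the same chain change would read alike with the 2-methoxyphenyl group of compound 1.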